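Dropping the chain chloro from a nitrobenzyl oxadiazole thioether

The compounds below may be only part of what the source reports. "The series", "measured", "known", "first", "only" and "open" are said of these compounds alone.

Compound 1 `ClCCCSc1nnc(Cc2ccc(Cl)cc2Cl)o1` gives in a functional assay on HepG2 cells (Homo sapiens) for cytotoxicity, with a stated time of 5 days (on this read-out higher numbers stand for lower toxicity in this test and lower numbers for higher toxicity in this test), only a limit of > 50000 nM. Compound 2 `CCCSc1nnc(COc2cccc([N+](=O)[O-])c2)o1` likewise reaches only a limit of > 50000 nM in this assay. Compound 3 `O=[N+]([O-])c1cccc(Cc2nnc(SCCCCl)o2)c1` also stands at a limit of > 50000 nM in this assay. Among the compounds with values here, all three recorded values sit at the same limit (the limit of > 50000 nM in this assay, at which 3 of the 3 values shown sit), so the numbers leave compound 3 indistinguishable from its two companions: no compound in this set has been resolved to a number.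

Compound 4 `CCCSc1nnc(Cc2cccc([N+](=O)[O-])c2)o1` differs from compound 3 by hydrogen in place of chloro on a saturated chain carbon, three bonds along the chain from a sulfur; read one bond further out, the change is 3-chloropropyl to propyl. Within the data shown here, no step between two measured compounds is recorded here. Because every shown value rests at the limit (the limit of > 50000 nM in this assay, at which 3 of the 3 values shown sit), no step beyond the scatter in this assay is expected in either direction, and the estimated step that the limit leaves unreadable from compound 3 to compound 4 is essentially flat. Compound 4 is therefore expected to give about 60000 nM in this assay, within a range from 30000 nM to 150000 nM, most likely again reported as a limit.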

Compound 4, half-maximal cytotoxic concentration: > 50000 nM
Compound 4 ended at the assay's limit (the forecaster's own chance of this, stated with the estimate: 85%); the middle value does not contradict the limit.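

Compound 3 and compound 4 both rest at a limit in this assay, and no step can be read between them: the limit of > 50000 nM in this assay, at which 4 of the 4 values shown sit.

The compounds shown leave open whether 3-chloropropyl and propyl differ at all in this assay.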